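A few compounds are considered here, and "the series" means these few. Any claim that something is new, unique, unknown or untested is made for them only; others in the source may bear on it.

Compound 3 `CC(C)[C@H](NC(=O)COc1cccc2ccccc12)C(=O)N[C@@H](CC(=O)O)C(=O)COc1ccc([N+](=O)[O-])cc1` sits at the edge of a functional assay on Jurkat cells (Homo sapiens); on this read-out lower numbers stand for stronger inhibition and higher numbers for weaker inhibition: in this assay compound 3 gives > 100000 nM, a limit rather than a number. Compound 1 `CC(C)[C@H](NC(=O)COc1cccc2ccccc12)C(=O)N[C@@H](CC(=O)O)C(=O)COc1ccc(C(N)=O)cc1` likewise gives > 100000 nM, also a limit. Among the compounds with values here, compound 2 `CC(C)[C@H](NC(=O)COc1cccc2ccccc12)C(=O)N[C@@H](CC(=O)O)C(=O)COc1ccc(Oc2ccccc2)cc1` gives 12700 nM, the only actual number in the set, so that the limit of > 100000 nM in this assay, at which 2 of the 3 values shown sit, holds the other two values. Compound 4 `CC(C)[C@H](NC(=O)COc1cccc2ccccc12)C(=O)N[C@@H](CC(=O)O)C(=O)COc1cc(F)c(F)cc1F` differs from compound 3 by 2,4,5-trifluorophenyl in place of 4-nitrophenyl on an oxygen on a saturated carbon. The measured steps that touch this position are an at least 7.8-fold higher number from compound 2 to compound 3 (0.89 log units; beyond the scatter) and a step that the two limits leave unreadable from compound 1 to compound 3; neither involves 2,4,5-trifluorophenyl. They show that a change on this oxygen can move the read-out beyond the scatter, but give no direction for 2,4,5-trifluorophenyl. Compound 4 is expected near 40000 nM, within 8000 nM to 150000 nM, which means an estimated at least 2.5-fold lower number from compound 3 to compound 4 (0.39 log units; beyond the scatter).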

Compound 4, half-maximal inhibitory concentration: 39300 nM
Compound 4: the middle estimate sits 1.0-fold (0.01 log units) above what was measured; low and high end bracket the measured number.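

In this assay, a ring without the phenoxy group of compound 2 also gives a measured number when 2,4,5-trifluorophenyl sits on this oxygen: an at least 2.5-fold lower number from compound 3 to compound 4 (0.40 log units; beyond the scatter), and an at least 2.5-fold lower number from compound 1 to compound 4 (0.40 log units; beyond the scatter). Both steps are bounds rather than sizes, because compound 1 and compound 3 each stand at a limit: the limit of > 100000 nM in this assay, at which 2 of the 4 values shown sit.

Which of the three fluorines matters cannot be told from compound 4 alone. Also open, from the compounds shown here alone, is whether an amine or a carboxylic acid on this ring, or a longer chain in place of the ring, would give a measured number.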